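Aryl imine variation on a shared pyridylidene thiazolidinone core

A few compounds are considered here, and "the series" means these few. Any claim that something is new, unique, unknown or untested is made for them only; others in the source may bear on it.

Measured so far:
- compound 1, `Cc1cccc(/N=C2/NC(=O)/C(=C/c3ccccn3)S2)c1`: 52.3%
- compound 2, `O=C1N/C(=N/c2ccc([N+](=O)[O-])cc2Cl)S/C1=C\c1ccccn1`: 37.4%

Of the compounds shown here, two have been measured in a functional assay on the whole organism (strain Swiss albino) for inhibition, with Mus musculus as the target, in the writhing test, with stated times of 30 min and 15 min, at a dose of 50 mg/kg by the oral route; on this read-out lower numbers stand for less inhibition and higher numbers for more inhibition at the one dose given (going by the name of the read-out). Compound 1 gives 52.3% and stands highest of the two numbers. Within the data shown here, its nearest neighbour is compound 2, which gives 37.4%, a number lower by a margin that lies beyond the scatter; the two structures differ in more than one place, so no single step between them can be read off.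

Compound 3, `O=C1N/C(=N/c2ccc(Br)cc2)S/C1=C\c1ccccn1`, has not yet been measured. It differs from compound 1 in one place: 4-bromophenyl in place of 3-methylphenyl on a double-bonded nitrogen. The group that leaves and the group that enters match in heavy-atom count and carry no donors or acceptors, so the change is a swap of substituent type on the aryl imine.

Among the measured compounds shown here, no step between measured compounds is available to anchor the swap. For the measured compounds named here, the only comparison, compound 1 against compound 2, shows that a different aryl substitution brought a lower number, but that pair changes two positions at once. The expected step of a number 7.3 percentage points lower from compound 1 to compound 3 (within the scatter) is therefore a modest decrease, not certain to clear the scatter. Compound 3 is expected to give about 45%, in the range 30% to 60%.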

Compound 3, a percentage reported as inhibition, in the whole organism at one dose (the size of the read-out at that dose, not a potency): 28.7%
Beside the measured number, compound 3's estimate is 16.3 percentage points above it, outside the stated range (below it).
By their numbers in this assay, from the lowest: compounds 3 and 2 (each within the scatter of the next); then compound 1.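

In this assay, among these compounds, a number 23.6 percentage points lower from compound 1 to compound 3 (beyond the scatter) is the first step that can be read at a single place: the shared core stays the same, and only the aryl group on the double-bonded nitrogen changes. The 3-methylphenyl and 4-bromophenyl groups match in heavy-atom count, each has one six-membered aromatic ring of carbon only, and neither has hydrogen-bond donors or acceptors, so these counts do not account for a step beyond the scatter, and the read-out at this dose depends on more than they capture. No measurement in hand bears on what lies behind this step.

The step exchanges the substituent and also its place on the phenyl ring, so the compounds shown cannot tell the effect of replacing methyl with bromine from that of moving the substituent. They also leave open how this read-out would respond to a phenyl ring carrying an amine or a carboxylic acid on the same nitrogen of the shared core.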